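The compounds below may be only part of what the source reports. "The series", "measured", "known", "first", "only" and "open" are said of these compounds alone.

In an ADME assay on LLC-PK1 cells (Sus scrofa) for permeability, with a stated time of 3 h, tested at 1 uM (on this read-out higher numbers stand for higher permeability and lower numbers for lower permeability), compound 1 (`O=C(O)CNC(=O)c1c(O)c2c(n(Cc3ccc(C(F)(F)F)cc3)c1=O)COCC2`) gives 7.3 10^-6 cm/s and compound 2 (`O=C(O)CNC(=O)c1c(O)c2c(n(Cc3ccc(C(F)(F)F)cc3)c1=O)COC2`) gives 4.2 10^-6 cm/s while compound 3 (`O=C(O)CNC(=O)c1c(O)c2c(n(Cc3ccc(Cl)cc3)c1=O)COC2`) gives 2.5 10^-6 cm/s on the same read-out. Compound 3 thus sits within the scatter of compound 2 and beyond the scatter under compound 1. Compound 4 (`O=C(O)CNC(=O)c1c(O)c2c(n(Cc3ccc(OC(F)(F)F)cc3)c1=O)COC2`) has trifluoromethoxy in place of chloro on an aromatic carbon, para to a large group (trifluoromethoxy in place of chloro on an aromatic carbon). Going by the values given here, the one measured step at this place is a 1.7-fold lower number from compound 2 to compound 3 (0.23 log units; within the scatter) for chloro in place of trifluoromethyl, and it lies within the scatter. Resting on that step alone, a small rise that stays within the scatter is expected in this assay and the expected step is a 1.5-fold higher number from compound 3 to compound 4 (0.18 log units; within the scatter) in that direction. Compound 4 is estimated at 3.8 10^-6 cm/s (range 2 10^-6 cm/s to 7 10^-6 cm/s).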

Compound 4, apparent permeability: 5.2 10^-6 cm/s
The estimate for compound 4 lay 1.4-fold (0.14 log units) below the measured number; the range from low to high includes it.
By their numbers in this assay, from the lowest: compounds 3, 2, 4 and 1 (each within the scatter of the next, the first and the last beyond it).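

At this place, on an aromatic carbon para to a large group, this assay now shows a step beyond the scatter: a 2.1-fold higher number from compound 3 to compound 4 (0.32 log units; beyond the scatter). Set against trifluoromethyl, however, trifluoromethoxy gives only a 1.2-fold higher number from compound 2 to compound 4 (0.09 log units; within the scatter), so these two groups cannot be told apart here, while chloro is separated from trifluoromethoxy but not from trifluoromethyl. Nothing measured here bears on the reason for this step. On these data alone, it remains open how a methoxy, a nitrile or an amine at this place would compare, and whether the change from chloro to trifluoromethoxy would give a similar step on the core of compound 1.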